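Methoxy in place of hydroxy on an amide of the shared core

This account rests on a few compounds, and the source may have more. Where it says the series, first, only, none or still open, it means among the compounds named here.

Measured compounds:
Compound 1 `O=C(Nc1ccccc1C(F)(F)F)c1nccc2ccccc12` — > 10000 nM
Compound 2 `O=C(Nc1ccccc1O)c1nccc2ccccc12` — > 10000 nM

Compound 1 `O=C(Nc1ccccc1C(F)(F)F)c1nccc2ccccc12` carries a trifluoromethyl on the aniline ring, and compound 2 `O=C(Nc1ccccc1O)c1nccc2ccccc12` carries a hydroxy in its place. In a functional assay on NUGC-3 cells (Homo sapiens) for inhibition, read by sulforhodamine B assay, with a stated time of 48 h (a higher number here means a weaker inhibitor of growth, a lower number a stronger inhibitor of growth), compound 1 gives > 10000 nM, which is a limit of the assay and not a number. In this assay compound 2 likewise gives > 10000 nM, again a limit. The step that the two limits leave unreadable from compound 1 to compound 2 therefore cannot be read, since (the limit of > 10000 nM in this assay, at which 2 of the 2 values shown sit).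

Compound 2 thus stands at the limit of this assay, and no measured value on this core lies anywhere else. Compound 3 `COc1ccccc1NC(=O)c1nccc2ccccc12` differs from compound 2 by methyl in place of hydrogen on an oxygen on an aromatic ring. For the measured compounds named here, the only measured step on this core, a step that the two limits leave unreadable from compound 1 to compound 2, gives no readable size and so no guide to the direction or size of this change; what the two limits show is that neither measured compound reached a number in this assay. With nothing but limits to rest on, compound 3 is expected to give a step that the limit leaves unreadable from compound 2 to compound 3 and most probably to sit at the limit as well. The estimate for compound 3 in this assay is 15000 nM, within 4000 nM to 60000 nM.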

Compound 3, concentration for 50% growth inhibition: > 10000 nM
Compound 3: a limit, no number; the forecaster's own chance of this, stated with the estimate: 80%; the middle value does not contradict the limit.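

In this assay compound 3 gives > 10000 nM, which is a limit of the assay and not a number. For the compounds shown here, no step among compound 1, compound 2 and compound 3 can therefore be read: the limit of > 10000 nM in this assay, at which 3 of the 3 values shown sit.

The compounds shown leave open how strongly any of the three inhibits growth, and whether the groups exchanged among them differ at all in this respect.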